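The source may hold more compounds than are shown below. What is called first, only, known or untested is meant among the compounds shown, and "the series" means these compounds.

Measured compounds:
- compound 1 `COc1ccccc1/C=C/C[C@H]1C[C@@H]([C@@H](O)c2ccccc2)CO[C@@H]1c1ccccc1`: 14700 nM
- compound 2 `COc1ccc(/C=C/C[C@H]2C[C@@H]([C@@H](O)c3ccccc3)CO[C@@H]2c2ccc(OC)c(OC)c2)cc1OC`: 15500 nM

In a functional assay on HeLa cells (Homo sapiens) for cytotoxicity, read by WST assay, with a stated time of 48 h (on this read-out higher numbers stand for weaker inhibition and lower numbers for stronger inhibition), compound 1 gives 14700 nM and compound 2 gives 15500 nM; the two numbers sit within the usual scatter of each other, so neither stands apart. Compound 3 `C=CC[C@H]1C[C@@H]([C@@H](O)c2ccccc2)CO[C@@H]1c1ccccc1` is not yet measured. It differs from compound 1 by vinyl in place of 2-(2-methoxyphenyl)ethenyl on a saturated chain carbon bound to a saturated ring carbon. Within the data shown here, no measured pair shows the effect of such a change, so the expectation rests on compound 1 alone. A modest step toward weaker inhibition in this assay is expected, a 1.7-fold higher number from compound 1 to compound 3 (0.23 log units; within the scatter), with the range wide. Compound 3 is estimated at 25000 nM, between 8000 nM and 80000 nM.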

Compound 3, half-maximal inhibitory concentration: 25400 nM
Beside the measured number, compound 3's estimate is 1.0-fold (0.01 log units) below it; low and high end bracket the measured number.
By their numbers in this assay, from the lowest: compounds 1, 2 and 3 (each within the scatter of the next).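

In this assay, among these compounds, vinyl in place of 2-(2-methoxyphenyl)ethenyl on a saturated chain carbon bound to a saturated ring carbon gives a 1.7-fold higher number from compound 1 to compound 3 (0.24 log units; within the scatter) as the first single-place comparison. At this position, the six-membered aromatic ring and its methoxy group can therefore go without a step beyond the scatter. No available evidence bears on this result. As far as these compounds go, whether an amine, a carboxylic acid or a longer chain at this position would move the number beyond the scatter remains open.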